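Removing a fluoro group: cytotoxicity of compound 4 anticipated

This account rests on a few compounds, and the source may have more. Where it says the series, first, only, none or still open, it means among the compounds named here.

Measured compounds:
- compound 1, `Cc1ccc(-c2ccc(C(=O)N[C@@H](c3nc(C)c(CO)s3)[C@@H]3CCCCN3)[nH]2)cc1F`: 19200 nM
- compound 2, `Cc1nc([C@@H](NC(=O)c2ccc(-c3ccc(Cl)c(F)c3)[nH]2)[C@@H]2CCCCN2)sc1CCO`: 16100 nM
- compound 3, `Cc1nc([C@H](NC(=O)c2ccc(-c3ccc(Cl)c(F)c3)[nH]2)[C@@H]2CCCCN2)sc1CCO`: 15100 nM

All three were tested in a toxicity assay on TZM cells (Homo sapiens) for cytotoxicity, read by XTT assay, with a stated time of 3 days; on this read-out higher numbers stand for lower toxicity in this test and lower numbers for higher toxicity in this test. In this assay compound 1 gives 19200 nM, compound 2 gives 16100 nM, and compound 3 gives 15100 nM. Compound 3 holds the lowest of the three numbers, but its distance to compound 2 and to compound 1 lies within the scatter, so the three cannot be told apart on these data. Within the data shown here, the one single-point step recorded is a 1.1-fold lower number from compound 2 to compound 3 (0.03 log units; within the scatter), which rests on the fact that compounds 2 and 3 differ only in the configuration as drawn and shows no change beyond the scatter.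

Compound 4, `Cc1nc([C@H](NC(=O)c2ccc(-c3ccc(Cl)cc3)[nH]2)[C@@H]2CCCCN2)sc1CCO`, has not yet been measured. It differs from compound 3 by hydrogen in place of fluoro on an aromatic carbon. Among the measured compounds shown here, no measured pair tests this change, so the only guide is the narrow spread of the three numbers seen so far, all within scatter of one another. A step of similar size is therefore expected for compound 4 in this assay, namely a 1.0-fold lower number from compound 3 to compound 4 (0.00 log units; within the scatter), with no direction beyond the scatter. Compound 4 is accordingly estimated at 15000 nM, with a range from 7000 nM to 32000 nM.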

Compound 4, half-maximal cytotoxic concentration: 15400 nM
Compound 4: middle estimate off by 1.0-fold (0.01 log units), on the low side; the measured number falls inside the stated range.
By their numbers in this assay, from the lowest: compounds 3, 4, 2 and 1 (each within the scatter of the next).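

Replacing fluoro by hydrogen on the aromatic carbon ortho to a chloro group, with the rest of the molecule held fixed, is tested directly in this assay and gives a 1.0-fold higher number from compound 3 to compound 4 (0.01 log units; within the scatter) and so no change that can be told from the scatter. The earlier compounds shown here could speak only to a change of configuration, whereas this pair shows that, in this one setting, going from 4-chloro-3-fluorophenyl to 4-chlorophenyl also leaves the cytotoxicity number where it stood. Nothing in the information at hand explains why this swap leaves the number in place.

Among these compounds, a single pair covers only this position and this swap, so it remains open whether a methoxy, nitrile or trifluoromethyl group at the same place would also stay within the scatter, or whether removing the chloro group itself would move the number. Among the compounds shown here, it is also open whether the same swap would behave alike in the other drawn configuration, the one carried by compound 2, or on a core with a different side chain on the sulfur-containing ring's neighbour.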